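Swapping the Benzyl Substituents on a Nucleoside Scaffold

A few compounds are considered here, and "the series" means these few. Any claim that something is new, unique, unknown or untested is made for them only; others in the source may bear on it.

This account follows a pair of closely related benzylamino nucleosides and one analogue that has not yet been measured. Within the data shown here, compound 2 `Cc1ccc(CNc2ncnc3c2ncn3[C@@H]2O[C@H](CO)[C@@H](O)[C@H]2O)cc1[N+](=O)[O-]` carries a 4-methyl-3-nitrophenyl group on a saturated chain carbon bound to a nitrogen on an aromatic ring; in an assay on isolated protein for binding affinity to Equilibrative nucleoside transporter 1 (Homo sapiens) (a higher number here means a weaker inhibitor, a lower number a stronger inhibitor), compound 2 gives 1170 nM, the lowest of the two numbers known so far. Among the measured compounds shown here, its only neighbour is compound 1 `Cc1ccc([N+](=O)[O-])c(CNc2ncnc3c2ncn3[C@@H]2O[C@H](CO)[C@@H](O)[C@H]2O)c1`, which in this assay gives 1290 nM; the step of a 1.1-fold lower number from compound 1 to compound 2 (0.04 log units; within the scatter) merely moves the methyl and nitro groups around the same ring and stays within the scatter.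

Compound 3 `COc1cccc(CNc2ncnc3c2ncn3[C@@H]2O[C@H](CO)[C@@H](O)[C@H]2O)c1` differs from compound 2 as follows: 3-methoxyphenyl in place of 4-methyl-3-nitrophenyl on a saturated chain carbon bound to a nitrogen on an aromatic ring. For the measured compounds named here, no measured step mirrors this exchange, since the one step available only relocates substituents rather than replacing them. Because the step of a 1.1-fold lower number from compound 1 to compound 2 (0.04 log units; within the scatter) shows the shared core tolerating a rearranged phenyl without a clear shift, compound 3 is expected to land near compound 2, with the direction uncertain. For compound 3 the estimate in this assay is 1500 nM, with a range from 400 nM to 5500 nM, which amounts to an expected step of a 1.3-fold higher number from compound 2 to compound 3 (0.11 log units; within the scatter).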

Compound 3, half-maximal inhibitory concentration: 115000 nM
The estimate for compound 3 lay 77-fold (1.88 log units) below the measured number; measured number above the stated range.
By their numbers in this assay, from the lowest: compounds 2 and 1 (each within the scatter of the next); then compound 3.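

Moving the methyl and nitro groups around the ring had produced no readable change, but replacing them shows that this position is far from indifferent to what the phenyl ring carries. In this assay, the exchange for 3-methoxyphenyl on a saturated chain carbon bound to a nitrogen on an aromatic ring gives a large step whether it starts from the 4-methyl-3-nitrophenyl group (a 98-fold higher number from compound 2 to compound 3 (1.99 log units; beyond the scatter)) or from the 5-methyl-2-nitrophenyl group (an 89-fold higher number from compound 1 to compound 3 (1.95 log units; beyond the scatter)). The two nitro-bearing compounds thus stay within the scatter of each other, while compound 3, which has a methoxy group and neither a nitro nor a methyl group, stands well apart from both, and no measurement at hand accounts for this gap.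

The compounds shown leave open which part of the exchange carries the step, since compound 3 differs from compound 1 and compound 2 at once in losing the nitro group, losing the methyl group and gaining the methoxy group. They also leave open how a ring with a nitro group alone, a methyl group alone, an amine or a carboxylic acid would fall in this assay relative to these three compounds.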